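Compound 4 against its ethyl isomer, compound 2

The compounds below may be only part of what the source reports. "The series", "measured", "known", "first", "only" and "open" are said of these compounds alone.

Measured in a functional assay on A549 cells (Homo sapiens) for inhibition, read by CCK-8 assay, with a stated time of 72 h, tested at 8 uM; a lower number here means less inhibition of growth, a higher number more inhibition of growth at the concentration tested:
compound 1 (`Nc1ccccc1NC(=O)/C=C/c1ccc(CSc2cccc(F)c2)cc1`) gives 56.6%
compound 2 (`CCc1ccc(SCc2ccc(C(=O)Nc3ccccc3N)cc2)cc1`) gives 91.4%
compound 3 (`CC(C)(C)c1ccc(SCc2ccc(/C=C/C(=O)Nc3ccccc3N)cc2)cc1`) gives 79.8%

Of these three, compound 2 stands highest, and compound 3 and compound 1 both lie beyond the scatter under it. Compound 4 (`Cc1cc(C)cc(SCc2ccc(C(=O)Nc3ccccc3N)cc2)c1`) keeps the core of compound 2 and carries 3,5-dimethylphenyl in place of 4-ethylphenyl on a sulfur. Within the data shown here, only one measured step bears on this swap, and only indirectly. It is the change a number 23.2 percentage points higher from compound 1 to compound 3 (beyond the scatter), a modest step that puts 4-(tert-butyl)phenyl in place of 3-fluorophenyl on a sulfur, on a core other than that of compound 2. Among the measured compounds shown here, it shows that the group on the sulfur can move the number, but no measured step compares the two groups at issue here. With compound 2 already the highest of the three, a small fall is expected, near the scatter, and the estimated step in this assay is a number 8.4 percentage points lower from compound 2 to compound 4 (within the scatter) overall. For compound 4 the expected value is 83%, within an estimated range from 64% to 96% overall.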

Compound 4, percent growth inhibition at one concentration: 78.5%
The estimate for compound 4 lay 4.5 percentage points above the measured number; low and high end bracket the measured number.
By their numbers in this assay, from the lowest: compound 1; then compounds 4 and 3 (each within the scatter of the next); then compound 2.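

Among these compounds, putting 3,5-dimethylphenyl in place of 4-ethylphenyl on a sulfur gives a number 12.9 percentage points lower from compound 2 to compound 4 (beyond the scatter) in this assay, the only direct reading of this position on the core of compound 2. The two groups have the same heavy-atom count, all carbon, and the same single aromatic ring, so the number at this position responds to how those carbons are arranged, which the earlier change between unlike groups on a different core could not show. Nothing available explains this difference.

On these data alone, it remains open whether the fall follows from losing the ethyl group or from gaining the two methyl groups. As far as these compounds go, how a phenyl carrying a methoxy group or an amine would behave on the sulfur of this core also stays unknown.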